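Benzyl on the ring oxygen: from compound 3 to compound 4

The compounds below may be only part of what the source reports. "The series", "measured", "known", "first", "only" and "open" are said of these compounds alone.

Measured so far:
compound 1, `NCC(N)CCC(=O)N1CCN(C(=O)CCn2cccc(O)c2=O)CC1`, 76.5%
compound 2, `NCC(N)CCCNC(=O)CCn1cccc(O)c1=O`, 76.8%
compound 3, `NCC(N)CCCCNC(=O)CCn1cccc(O)c1=O`, 87%

Within the data shown here, in a physicochemical assay, read by spectrophotometry, with a stated time of 10 min, tested at 2 mM, in the presence of a further agent that is not named here (a higher number here means a stronger effect of the compound at the concentration tested, a lower number a weaker effect), compound 3 gives the highest of the three numbers; compound 2 and compound 1 lie beyond the scatter below it, and the one measured step, a number 10.2 percentage points higher from compound 2 to compound 3 (beyond the scatter), is modest. Compound 4, `NCC(N)CCCCNC(=O)CCn1cccc(OCc2ccccc2)c1=O`, differs from compound 3 in one place: benzyl in place of hydrogen on an oxygen on an aromatic ring. Among the measured compounds shown here, no measured step touches this oxygen; the three compounds differ only in the diamine part of the chain. The change is therefore untested here, and the expectation rests on no comparison. The estimate for compound 4 in this assay is 20%, expected within 0% to 55%, an expected step of a number 67 percentage points lower from compound 3 to compound 4 (beyond the scatter).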

Compound 4, a percentage reported as activity, at one concentration (the size of the read-out at that concentration, not a potency): 67.8%
Compound 4: middle estimate off by 47.8 percentage points, on the low side; the whole stated range lies below it.
By their numbers in this assay, from the lowest: compounds 4, 1 and 2 (each within the scatter of the next); then compound 3.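

In this assay, the change from hydroxy to benzyloxy gives a number 19.2 percentage points lower from compound 3 to compound 4 (beyond the scatter), the first measured sign that changing this oxygen matters. The effect does not vanish, however: compound 4 still gives 67.8%, so a free hydroxy on this oxygen is not essential for a sizeable reading. Nothing available explains the size of this drop.

Going by these compounds, it remains open whether methyl on this oxygen, in place of benzyl, would lower the number as far. It is also unknown how a benzyl group carrying a carboxylic acid would behave there.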